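The source may report more compounds than this note shows. Statements on the series, on what has been measured and on what is new or still open speak of the compounds shown alone.

Measured in a functional assay on K562 cells (Homo sapiens), read by MTT assay, with a stated time of 72 h; on this read-out higher numbers stand for weaker inhibition and lower numbers for stronger inhibition:
- Compound 1 `CSc1ncnc2c1c(-c1ccoc1)cn2[C@@H]1O[C@H](CO)[C@@H](O)[C@H]1O`: 3250 nM
- Compound 2 `CSc1ncnc2c1c(-c1ccsc1)cn2[C@@H]1O[C@H](CO)[C@@H](O)[C@H]1O`: > 20000 nM, a limit of the assay and not a number
- Compound 3 `C#Cc1cn([C@@H]2O[C@H](CO)[C@@H](O)[C@H]2O)c2ncnc(SC)c12`: 70 nM

Compound 3 holds the lowest number in the series, and the nearest number is that of compound 1 at 3250 nM. Compound 4 `C#Cc1cn([C@@H]2O[C@H](CO)[C@@H](O)[C@H]2O)c2ncnc(N(C)C)c12` keeps the ethynyl group of compound 3 and carries one change: dimethylamino in place of methylsulfanyl on an aromatic carbon.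

Among the measured compounds shown here, no measured step touches this place, so the available steps bear on it only indirectly. All three concern the group that ethynyl occupies in compound 3: an at least 6.1-fold higher number from compound 1 to compound 2 (0.78 log units; beyond the scatter) is at least modest, while a 46-fold lower number from compound 1 to compound 3 (1.67 log units; beyond the scatter) and an at least 280-fold lower number from compound 2 to compound 3 (2.45 log units; beyond the scatter) are large. In these compounds a single swap moves the number far. A step beyond the scatter is therefore expected in this assay, of moderate size and toward a higher number, as compound 3 at 70 nM sits at the low end. The estimated change is an 11-fold higher number from compound 3 to compound 4 (1.06 log units; beyond the scatter). For compound 4 the expected value is 800 nM, with an estimated range of 120 nM to 6000 nM.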

Compound 4, half-maximal inhibitory concentration: 260 nM
Estimate against measurement, compound 4: 3.1-fold (0.49 log units) above; measured number inside the range.
By their numbers in this assay, from the lowest: compound 3; then compound 4; then compound 1. At a limit, above all of these: compound 2.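

In this assay, among the compounds shown here, dimethylamino in place of methylsulfanyl gives a 3.7-fold higher number from compound 3 to compound 4 (0.57 log units; beyond the scatter), the first reading of any change at this position on the six-membered aromatic ring with 2 nitrogen. The position therefore responds to substitution, yet this step is modest, while the two steps that replace furan-3-yl or thiophen-3-yl with ethynyl are both large, so with ethynyl held fixed this swap costs comparatively little. Nothing shown here accounts for the size or direction of this step.

On these data alone, it remains open whether the same swap gives a similar step with furan-3-yl or thiophen-3-yl in place of ethynyl. How a primary amine, a methoxy group or a longer chain such as ethylsulfanyl would read at this position is also unresolved.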